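This account rests on a few compounds, and the source may have more. Where it says the series, first, only, none or still open, it means among the compounds named here.

Values measured so far in an ADME assay on MT4 cells (Homo sapiens) for cytotoxicity, read by XTT assay, with a stated time of 3 days (a higher number here means that more compound is tolerated, a lower number that less compound is tolerated), are:

compound 1 `CCOCn1c(Cc2cc(C)cc(C)c2)c(I)c(=O)[nH]c1=O` gives 142000 nM
compound 2 `O=c1[nH]c(=O)n(COCc2ccccc2)c(Cc2ccccc2)c1I` gives 74800 nM

Within the data shown here, these two values lie within the scatter of each other, so compound 1 stands level with the only other number. The step to compound 3 `Cc1cc(C)cc(Cc2c(I)c(=O)[nH]c(=O)n2COCc2ccccc2)c1` is phenyl in place of methyl on a saturated chain carbon bound to an oxygen on a saturated carbon and reads as phenyl in place of methyl on a saturated chain carbon bound to an oxygen on a saturated carbon, or ethoxymethyl to (benzyloxy)methyl. Among the measured compounds shown here, no measured pair isolates this change. For the measured compounds named here, the (benzyloxy)methyl group also stands in compound 2 at 74800 nM and this is the only guide, so in this assay a small step towards lower numbers is expected, at most slightly beyond the scatter. The expected move a 2.0-fold lower number from compound 1 to compound 3 (0.31 log units; beyond the scatter) is an estimate only. For compound 3 an estimated value of 70000 nM is expected, within a range of 22000 nM to 200000 nM as a working guess.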

Compound 3, half-maximal cytotoxic concentration: 98300 nM
For compound 3 the middle estimate is 1.4-fold (0.15 log units) below the measured one; the measured number falls inside the stated range.
By their numbers in this assay, from the lowest: compounds 2, 3 and 1 (each within the scatter of the next).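

In this assay, the exchange of ethoxymethyl for (benzyloxy)methyl can now be read with the 3,5-dimethylphenyl group held constant, as a 1.4-fold lower number from compound 1 to compound 3 (0.16 log units; within the scatter), so phenyl in place of methyl on a saturated chain carbon bound to an oxygen on a saturated carbon leaves the read-out level with the starting compound. The second place can also be read with (benzyloxy)methyl held constant, as a 1.3-fold higher number from compound 2 to compound 3 (0.12 log units; within the scatter), so 3,5-dimethylphenyl in place of phenyl on a saturated chain carbon bound to an aromatic carbon also separates nothing. No supporting measurement bears on either step.

Going by these compounds, whether this tolerance extends to a primary amine or a carboxylic acid in place of the phenyl on that saturated chain carbon remains open. A longer chain in place of the ethoxymethyl group is equally untested among the compounds shown.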